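Adding a methoxy to the tyrosine ring of a macrocycle

The source may report more compounds than this note shows. Statements on the series, on what has been measured and on what is new or still open speak of the compounds shown alone.

Measured compounds:
- Compound 1, `CO[C@@H]1C/C=C(\C)C(=O)N(C)[C@@H](C(C)C)C(=O)N[C@H](Cc2cc(Cl)c(O)c(Cl)c2)C(=O)N[C@@H](C(C)C)C(=O)O[C@H](c2ccccc2)[C@H](C)/C=C/C=C/1C`: 42.1 nM
- Compound 2, `CO[C@@H]1C/C=C(\C)C(=O)N(C)[C@@H](C(C)C)C(=O)N[C@H](Cc2ccc(O)cc2)C(=O)N[C@@H](C(C)C)C(=O)O[C@H](c2ccccc2)[C@H](C)/C=C/C=C/1C`: 59.7 nM

Both compounds share one large cyclic core and were tested in a functional assay on HCT-116 cells (Homo sapiens) for antiproliferative activity, read by MTT assay, with a stated time of 72 h; a lower number here means a stronger inhibitor, a higher number a weaker inhibitor. Going by the values given here, compound 1 gives 42.1 nM and compound 2 gives 59.7 nM; the only step measured so far, a 1.4-fold higher number from compound 1 to compound 2 (0.15 log units; within the scatter), swapped a dichlorinated hydroxyphenyl for a plain hydroxyphenyl and changed the number by less than repeated testing would. Compound 2 holds the higher of the two numbers, but the gap to compound 1 lies within the scatter, so no order can be read from it.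

Compound 3, `COc1cc(C[C@H]2NC(=O)[C@H](C(C)C)N(C)C(=O)/C(C)=C/C[C@@H](OC)/C(C)=C/C=C/[C@@H](C)[C@@H](c3ccccc3)OC(=O)[C@H](C(C)C)NC2=O)ccc1O`, differs from compound 2 by methoxy in place of hydrogen on an aromatic carbon. This is a change on the same aromatic ring that the measured step altered, and that step moved little. The expectation is therefore a step of a 1.2-fold higher number from compound 2 to compound 3 (0.07 log units; within the scatter) in this assay, that is, no change beyond the scatter. Compound 3 is estimated at 70 nM, with a likely range from 25 nM to 200 nM.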

Compound 3, half-maximal inhibitory concentration: 48.5 nM
The estimate for compound 3 lay 1.4-fold (0.16 log units) above the measured number, and the stated range covers the measured number.
By their numbers in this assay, from the lowest: compounds 1, 3 and 2 (each within the scatter of the next).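

In this assay, a methoxy on the aromatic ring, ortho to the hydroxy group, gives a 1.2-fold lower number from compound 2 to compound 3 (0.09 log units; within the scatter) and so stays within the scatter. This position therefore carries a methoxy as well as the chlorines of compound 1 without a change that can be told apart from repeated testing, and replacing the dichlorinated ring with the methoxy ring gives a 1.2-fold higher number from compound 1 to compound 3 (0.06 log units; within the scatter), again within the scatter. No measurement shown here bears on the reason for this result.

As far as these compounds go, it remains open whether an amine, a carboxylic acid or a longer chain such as butoxy on this ring would also leave the number in place. From the compounds shown here alone, all three compounds keep the hydroxy group, so its own contribution also remains open.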